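The source may hold more compounds than are shown below. What is called first, only, known or untested is meant among the compounds shown, and "the series" means these compounds.

In a functional assay on K562 cells (Homo sapiens) for cytotoxicity, read by MTT assay, with a stated time of 72 h (a higher number here means a weaker inhibitor, a lower number a stronger inhibitor), compound 1 (`C=C1C(=O)[C@@]23C(=O)OC[C@]4(C(=O)CCC(C)(C)[C@H]4C=O)[C@@H]2CC[C@@H]1[C@H]3OC(=O)CC`) gives 1310 nM and compound 2 (`C=C1C(=O)[C@@]23C(=O)OC[C@]4(C(=O)CCC(C)(C)[C@H]4C=O)[C@@H]2CC[C@@H]1[C@H]3OC(=O)c1ccc(OC)cc1`) gives 1650 nM on the same core. Compound 2 therefore stands within the scatter of compound 1. Going by the values given here, the one measured step (a 1.3-fold higher number from compound 1 to compound 2 (0.10 log units; within the scatter)) puts 4-methoxyphenyl in place of ethyl on a carbonyl carbon and stays within the scatter. Compound 3 (`C=C1C(=O)[C@@]23C(=O)OC[C@]4(C(=O)CCC(C)(C)[C@H]4C=O)[C@@H]2CC[C@@H]1[C@H]3OC(=O)c1ccc(C(F)(F)F)cc1`) carries trifluoromethyl in place of methoxy on an aromatic carbon para to a large group. Among the compounds with values here, no measured step changes that aromatic substituent, so the only guide is the exchange of the whole group on the carbonyl carbon (a 1.3-fold higher number from compound 1 to compound 2 (0.10 log units; within the scatter)) which left the number within the scatter. No step beyond the scatter is expected in this assay and the data give no direction. The expected change (a 1.1-fold lower number from compound 2 to compound 3 (0.04 log units; within the scatter)) is estimated to lie within the scatter. For compound 3 the estimated value is 1500 nM with an expected range from 700 nM to 3200 nM in this assay.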

Compound 3, half-maximal inhibitory concentration: 2820 nM
The estimate for compound 3 lay 1.9-fold (0.27 log units) below the measured number; the range from low to high includes it.
By their numbers in this assay, from the lowest: compounds 1, 2 and 3 (each within the scatter of the next, the first and the last beyond it).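

In this assay, trifluoromethyl in place of methoxy on the aromatic carbon para to a large group gives (a 1.7-fold higher number from compound 2 to compound 3 (0.23 log units; within the scatter)), so this substituent exchange alone is not resolved from the scatter. Going by these compounds alone, measured against the ethyl group on the carbonyl carbon, however, 4-(trifluoromethyl)phenyl gives (a 2.2-fold higher number from compound 1 to compound 3 (0.33 log units; beyond the scatter)), the only step so far to pass the scatter, though modestly, whereas 4-methoxyphenyl gives (a 1.3-fold higher number from compound 1 to compound 2 (0.10 log units; within the scatter)). Nothing available bears on the reason for these differences.

The compounds shown leave open how an amine or a carboxylic acid on that aromatic carbon would read in this assay. They also leave open whether a longer chain in place of ethyl on the carbonyl carbon would move the number at all.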